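Replacing a bis-nitrile amide with an anilide

A few compounds are considered here, and "the series" means these few. Any claim that something is new, unique, unknown or untested is made for them only; others in the source may bear on it.

Compound 1 `CCn1c(C(=O)NCCCN(C)C)ccc1C(CC)(CC)c1ccc(OCCC(O)(CC)CC)c(C)c1`: 5 nM
Compound 2 `CCn1c(C(=O)N(CCC#N)CCC#N)ccc1C(CC)(CC)c1ccc(OCCC(O)(CC)CC)c(C)c1`: > 10000 nM

In an assay on cells for agonist activity at vitamin D3 receptor (Homo sapiens), with a stated time of 96 h (a lower number here means that less compound is needed, a higher number that more compound is needed for the effect), compound 1 gives 5 nM. For compound 2 the reported figure is only a limit of the assay, > 10000 nM, so it stands at the weak end of what is known here (the limit of > 10000 nM in this assay, at which 1 of the 2 values shown sits). The step of an at least 2000-fold higher number from compound 1 to compound 2 (3.30 log units; beyond the scatter) shows how far the bis(2-cyanoethyl) group moved the number. Compound 3 `CCn1c(C(=O)Nc2ccc(OC(F)(F)F)cc2)ccc1C(CC)(CC)c1ccc(OCCC(O)(CC)CC)c(C)c1` carries instead (a group of 12 heavy atoms (7 carbon, 1 nitrogen, 1 oxygen, 3 fluorine; one six-membered aromatic ring of carbon only) in place of a group of 9 heavy atoms (6 carbon, 3 nitrogen; no ring), on a carbonyl carbon), a secondary amide again as in compound 1. A large drop in the number is therefore expected, an at least 160-fold lower number from compound 2 to compound 3 (2.22 log units; beyond the scatter). Compound 3 is estimated at 60 nM, between 5 nM and 1500 nM.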

Compound 3, half-maximal effective concentration: > 10000 nM
Compound 3 was reported as a limit; the forecaster's own chance of this, stated with the estimate: 12%; at least 160-fold (2.22 log units) between middle value and limit.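

Compound 3 has the amide hydrogen back, now with 4-(trifluoromethoxy)phenyl on the amide-type nitrogen, yet this assay shows an at least 2000-fold higher number from compound 1 to compound 3 (3.30 log units; beyond the scatter). At this position, then, a secondary amide alone does not restore the activity of compound 1. Compound 2 and compound 3 both stand at a limit, so the step between them cannot be read: the limit of > 10000 nM in this assay, at which 2 of the 3 values shown sit.

On these data alone, it remains open whether the aromatic ring or the absence of the amine of 3-(dimethylamino)propyl matters more. A plain propyl chain or a benzyl group on the same nitrogen would help separate the two.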